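A few compounds are considered here, and "the series" means these few. Any claim that something is new, unique, unknown or untested is made for them only; others in the source may bear on it.

Working notes on the series. Going by the values given here, compound 1 `O=c1cc(/C=N\Nc2ccccc2)c2ccc(OCc3ccccc3)cc2o1` stands at the lower of the two numbers measured so far: in a functional assay, read by spectrophotometry, with a stated time of 3 min (a higher number here means a weaker inhibitor, a lower number a stronger inhibitor), compound 1 gives 13200 nM. Among the compounds with values here, its one neighbour, compound 2 `O=c1cc(/C=N\Nc2ccccc2)c2c(OCc3ccccc3)cc(OCc3ccccc3)cc2o1`, gives 40100 nM in this assay, and the step of a 3.0-fold higher number from compound 1 to compound 2 (0.48 log units; beyond the scatter) comes from benzyloxy in place of hydrogen on an aromatic carbon.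

Compound 3 `O=c1cc(/C=N\O)c2ccc(OCc3ccccc3)cc2o1` is not yet measured. It differs from compound 1 at a different place, (hydroxy in place of anilino on a double-bonded nitrogen). Within the data shown here, the single measured step, a 3.0-fold higher number from compound 1 to compound 2 (0.48 log units; beyond the scatter), touches an aromatic carbon and not the double-bonded nitrogen, so no measured step bears on this change; the data give no direction for it. The estimate for compound 3 in this assay is therefore kept near the parent with a wide spread, a step of a 1.5-fold higher number from compound 1 to compound 3 (0.18 log units; within the scatter) being expected. Compound 3 is estimated at 20000 nM, in the range 5000 nM to 80000 nM.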

Compound 3, half-maximal inhibitory concentration: 22800 nM
Compound 3: the middle estimate sits 1.1-fold (0.06 log units) below what was measured, and the stated range covers the measured number.
By their numbers in this assay, from the lowest: compounds 1, 3 and 2 (each within the scatter of the next, the first and the last beyond it).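

In this assay, hydroxy in place of anilino on the double-bonded nitrogen gives a 1.7-fold higher number from compound 1 to compound 3 (0.24 log units; within the scatter) and so stays within the usual scatter of repeated measurements. Going by these compounds alone, this is the first reading at this position, and it shows that a group with one six-membered aromatic ring of carbon can give way to a hydroxy group with no ring, while the hydrogen-bond donor and acceptor counts stay the same and compound 1 and compound 3 remain indistinguishable. No measured evidence accounts for this result.

From the compounds shown here alone, whether other groups on this nitrogen, such as methoxy, an amine or a longer chain, would also leave the number within the scatter remains open. Going by these compounds, it is also open whether the added benzyloxy of compound 2 would give a comparable step on the hydroxy compound 3.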